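Working notes on the ring substituent series, compound 4

This account rests on a few compounds, and the source may have more. Where it says the series, first, only, none or still open, it means among the compounds named here.

Three measured compounds share one core and differ only at one aromatic carbon. Compound 1 `O=C(Nc1ccnnc1)c1cc(C(F)(F)F)ccc1OCc1ccccc1` carries a trifluoromethyl group there and gives 15.9 nM in an assay on Sf9 cells for inhibition of Leucine-rich repeat serine/threonine-protein kinase 2 (Homo sapiens), read by TR-FRET, with stated times of 30 min and 2 h; on this read-out lower numbers stand for stronger inhibition and higher numbers for weaker inhibition. Compound 2 `O=C(Nc1ccnnc1)c1cc(N2C[C@H]3COC[C@H]3C2)ccc1OCc1ccccc1` gives 50.1 nM in this assay, and compound 3 `CN1CCN(c2ccc(OCc3ccccc3)c(C(=O)Nc3ccnnc3)c2)CC1` gives 12.6 nM. On these three numbers compound 3 sits at the low end, though not apart from compound 1: the step of a 1.3-fold lower number from compound 1 to compound 3 (0.10 log units; within the scatter) is within the scatter, while a 3.2-fold higher number from compound 1 to compound 2 (0.50 log units; beyond the scatter) and a 4.0-fold lower number from compound 2 to compound 3 (0.60 log units; beyond the scatter) are modest steps beyond it.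

Compound 4 `N#CC1CCN(c2ccc(OCc3ccccc3)c(C(=O)Nc3ccnnc3)c2)CC1` is not yet measured in this assay. Its change from compound 3 is 4-cyanopiperidin-1-yl in place of 4-methylpiperazin-1-yl on an aromatic carbon. All three measured steps at this aromatic carbon bear on it, and together they show that three quite different groups keep the numbers within a narrow band. Another six-membered ring with a nitrile is therefore expected to move the number little, with any shift more likely upward than downward, since the one step that left the scatter, a 4.0-fold lower number from compound 2 to compound 3 (0.60 log units; beyond the scatter), came from exchanging one ring for another. The expected step is a 1.6-fold higher number from compound 3 to compound 4 (0.20 log units; within the scatter), within the scatter. Compound 4 is estimated at 20 nM, with a range from 8 nM to 50 nM.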

Compound 4, half-maximal inhibitory concentration: 10 nM
Compound 4: middle estimate off by 2.0-fold (0.30 log units), on the high side, and the stated range covers the measured number.
By their numbers in this assay, from the lowest: compounds 4, 3 and 1 (each within the scatter of the next); then compound 2.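

With compound 4 a nitrile-bearing ring joins the tolerated groups at this aromatic carbon: in this assay neither (a 1.3-fold lower number from compound 3 to compound 4 (0.10 log units; within the scatter)) nor (a 1.6-fold lower number from compound 1 to compound 4 (0.20 log units; within the scatter)) leaves the scatter, so 4-cyanopiperidin-1-yl cannot be told apart from 4-methylpiperazin-1-yl or trifluoromethyl. The exchange of the methyl-bearing ring nitrogen and its methyl for a ring carbon with a nitrile therefore leaves the number unchanged within the scatter, and compound 2 alone stands apart, now also by (a 5.0-fold lower number from compound 2 to compound 4 (0.70 log units; beyond the scatter)). No measurement here accounts for these numbers.

Open, as far as these compounds go, is whether plain piperidin-1-yl reads like compound 4, which would separate the nitrile from the ring, and whether a carboxylic acid or a primary amine at this carbon stays with compounds 1, 3 and 4. Also open, from the compounds shown here alone, is whether this tolerance holds with methoxy in place of the benzyloxy group.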